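The source may hold more compounds than are shown below. What is called first, only, known or untested is meant among the compounds shown, and "the series" means these compounds.

Of the compounds shown here, two have been measured in an in vitro functional assay on cells for antagonist activity at B1 bradykinin receptor (Homo sapiens), read by luminescence and calcium flux, with a stated time of 2 h; on this read-out lower numbers stand for stronger inhibition and higher numbers for weaker inhibition. Compound 1 `Cc1ccc(S(=O)(=O)N2C=CNC(=O)[C@H]2CC(=O)N[C@@H]2CCCc3cc(CN4CCCCC4)ccc32)cc1` gives 0.115 nM in this assay. Compound 2 `Cc1ccc(S(=O)(=O)N2C=CNC(=O)[C@H]2CC(=O)N[C@H](C)c2ccccc2)cc1` is a much simpler molecule, and in this assay compound 2 gives 836 nM; that is the higher of the two numbers, far removed from compound 1, so of the two it is the weaker inhibitor.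

Compound 3 `CCN1CC[C@H](NC(=O)C[C@@H]2C(=O)NC=CN2S(=O)(=O)c2ccc(C)cc2)C(C)(C)C1` has not yet been measured. It keeps the core of compound 2 and changes only one part: a group of 10 heavy atoms (9 carbon, 1 nitrogen; one six-membered non-aromatic ring with 1 hetero atom) in place of a group of 8 heavy atoms (8 carbon; one six-membered aromatic ring of carbon only), on an amide-type nitrogen. The group that leaves is an aromatic ring of carbon only; the group that enters is a six-membered non-aromatic ring with one hetero atom and one hydrogen-bond acceptor.

Going by the values given here, no step of this kind between measured compounds is available, so the expectation rests only on the two values shown. The expected step of a 21-fold lower number from compound 2 to compound 3 (1.32 log units; beyond the scatter) is a move toward a lower number, by more than the usual scatter, because compound 1 gives 0.115 nM while carrying a ring with a hetero atom of its own. For compound 3 the estimated value in this assay is 40 nM, with a plausible range from 5 nM to 300 nM.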

Compound 3, half-maximal inhibitory concentration: 0.63 nM
Beside the measured number, compound 3's estimate is 63-fold (1.80 log units) above it; the measured number lies below the stated range.
By their numbers in this assay, from the lowest: compound 1; then compound 3; then compound 2.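

In this assay, putting the six-membered non-aromatic ring with its one hetero atom in place of 1-phenylethyl, on the amide-type nitrogen, gives a 1300-fold lower number from compound 2 to compound 3 (3.12 log units; beyond the scatter), so with the rest of the molecule unchanged, the group at this position has a very large bearing on the read-out. Going by these compounds alone, the result also shows that an aromatic ring is not needed here for a number as low as the one compound 3 gives, 0.63 nM, although this single step changes several things at once: the aromatic ring leaves, while a ring nitrogen and a hydrogen-bond acceptor enter in a larger group. Nothing available explains why the number falls so far.

As far as these compounds go, it remains open which of these changes carries the step, and a cyclohexyl group, a ring of carbon only, on the same nitrogen would help separate the ring's shape from its nitrogen. A plain piperidine ring, without the methyl groups of compound 3, would likewise show whether those methyl groups matter.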